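The compounds below may be only part of what the source reports. "The series", "measured", "known", "first", "only" and "open" are said of these compounds alone.

Compound 1 `O=C(CSC(=S)N[C@H]1CCOC1=O)Nc1ccc(Cl)cc1` — in a functional assay on SMMC-7721 cells (Homo sapiens) for cytotoxicity, read by MTT assay, with a stated time of 72 h (a lower number here means a stronger inhibitor, a higher number a weaker inhibitor), compound 1 gives > 128000 nM, which is a limit of the assay.
Compound 2 `COc1ccc(NC(=O)CSC(=S)N[C@H]2CCOC2=O)cc1` — in this assay compound 2 gives > 128000 nM, again a limit.
Compound 3 `CC(=O)c1ccc(NC(=O)CSC(=S)N[C@H]2CCOC2=O)cc1` — in this assay compound 3 gives > 128000 nM, also a limit.

Compound 3 therefore stands at the limit shared by every value shown (the limit of > 128000 nM in this assay, at which 3 of the 3 values shown sit). Compound 4 `O=C(CSC(=S)N[C@H]1CCOC1=O)Nc1ccc(C(=O)/C=C/c2ccc([N+](=O)[O-])cc2)cc1` differs from compound 3 by 2-(4-nitrophenyl)ethenyl in place of methyl on a carbonyl carbon. The measured steps a step that the two limits leave unreadable from compound 1 to compound 2, a step that the two limits leave unreadable from compound 1 to compound 3 and a step that the two limits leave unreadable from compound 2 to compound 3 all run between limits, so their sizes cannot be read, and none of them touches the carbonyl substituent that changes here. Within the data shown here, they give no direction for this step. Compound 4 is expected near 60000 nM, within 10000 nM to 128000 nM, an estimated step of an at least 2.1-fold lower number from compound 3 to compound 4 (0.32 log units; beyond the scatter), with a limit still a real possibility.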

Compound 4, half-maximal inhibitory concentration: > 128000 nM
Compound 4 was reported as a limit; the forecaster's own chance of this, stated with the estimate: 50%; at least 2.1-fold (0.32 log units) between middle value and limit.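

In this assay compound 4 gives > 128000 nM, a limit, so the step from compound 3 to compound 4 runs between two limits and cannot be read. The compounds shown leave open what any of their actual values is, and which structural change would alter them, as all stand at one limit: the limit of > 128000 nM in this assay, at which 4 of the 4 values shown sit.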